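A few compounds are considered here, and "the series" means these few. Any claim that something is new, unique, unknown or untested is made for them only; others in the source may bear on it.

In a functional assay on MDA-MB-231 cells (Homo sapiens) for antiproliferative activity, read by MTT assay, with a stated time of 48 h (a higher number here means a weaker inhibitor, a lower number a stronger inhibitor), three compounds have been measured so far:

Compound 1, `CCOC(=O)CN(Cc1ccccc1)c1nc(NCc2ccccc2)ncc1[N+](=O)[O-]`: 82400 nM
Compound 2, `COC(=O)CN(C)c1nc(NCc2ccccc2)ncc1[N+](=O)[O-]`: 61100 nM
Compound 3, `CCOC(=O)CNc1nc(NCc2ccccc2)ncc1[N+](=O)[O-]`: 22300 nM

Compound 1 gives the highest of the three numbers; compound 2 sits within the scatter of it, while compound 3 lies furthest away, a 3.7-fold lower number from compound 1 to compound 3 (0.57 log units; beyond the scatter). The other measured step, a 2.7-fold lower number from compound 2 to compound 3 (0.44 log units; beyond the scatter), likewise concerns the ester-bearing side of the core. Compound 4, `CCOC(=O)CN(Cc1ccccc1)c1nc(Nc2cc(OC)c(OC)c(OC)c2)ncc1[N+](=O)[O-]`, differs from compound 1 by 3,4,5-trimethoxyphenyl in place of benzyl on a nitrogen on an aromatic ring. Neither measured step touches that nitrogen, so nothing measured bears directly on this change. Compound 4 is therefore expected to give a number close to its parent, a step of a 1.4-fold lower number from compound 1 to compound 4 (0.14 log units; within the scatter), not expected to go beyond the scatter. The estimate for compound 4 is 60000 nM, between 12000 nM and 250000 nM.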

Compound 4, half-maximal inhibitory concentration: 40400 nM
Compound 4: middle estimate off by 1.5-fold (0.17 log units), on the high side; low and high end bracket the measured number.
By their numbers in this assay, from the lowest: compounds 3, 4, 2 and 1 (each within the scatter of the next, the first and the last beyond it).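

In this assay, the nitrogen carrying the benzyl in compound 1 proves to be a second place where a change moves the number: a 2.0-fold lower number from compound 1 to compound 4 (0.31 log units; beyond the scatter). Until now, only changes on the ester-bearing side had been seen to do so. The step is modest, but it shows that 3,4,5-trimethoxyphenyl, with more heavy atoms and three hydrogen-bond acceptors, does not weaken compound 1 here. Nothing available explains this step. A plain phenyl on that nitrogen could separate the effect of the methoxy groups from that of replacing benzyl with a directly attached ring.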